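This account rests on a few compounds, and the source may have more. Where it says the series, first, only, none or still open, it means among the compounds named here.

Compound 1, `CCOC(=O)C1=C(Nc2ccccc2)S/C(=C\c2ccc[nH]2)C1=O`, gives 23.5% in a functional assay on A549 cells (Homo sapiens) for inhibition, read by MTT assay, with a stated time of 72 h, tested at 10 uM; a higher number here means more inhibition at the concentration tested (going by the name of the read-out), a lower number less inhibition.
Compound 2, `CCOC(=O)C1=C(Nc2ccc(OC)cc2)S/C(=C\c2ccc[nH]2)C1=O`, reports only a limit in this assay, < 10%.
Compound 3, `CCOC(=O)C1=C(Nc2ccc(Br)cc2)S/C(=C\c2ccc[nH]2)C1=O`, likewise reports only a limit in this assay, < 10%.

Compound 3 therefore stands at the limit of this assay; as the limit of < 10% in this assay, at which 2 of the 3 values shown sit, shows, it is not alone there. The step to compound 4, `CCOC(=O)C1=C(Nc2ccc(F)cc2)S/C(=C\c2ccc[nH]2)C1=O`, is fluoro in place of bromo on an aromatic carbon. For the measured compounds named here, two measured steps bear on it: a number at least 13.5 percentage points lower from compound 1 to compound 3 (beyond the scatter) and a number at least 13.5 percentage points lower from compound 1 to compound 2 (beyond the scatter), both showing that any group at this place on the ring lowers the read-out at least modestly against hydrogen. The step that the two limits leave unreadable from compound 2 to compound 3 cannot be sized, since both ends sit at the limit. Fluoro is a third group at the same place, so a read-out near the limit is expected, with a step of a number no lower from compound 3 to compound 4 (the limit leaves the size open) that is not expected to reach beyond the scatter. Compound 4 is estimated at 10%, within a range of 4% to 24%, and may well again be reported only as a limit.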

Compound 4, a percentage reported as inhibition, at one concentration (the size of the read-out at that concentration, not a potency): < 10%
Compound 4 gave a limit, no number; the forecaster's own chance of this, stated with the estimate: 55%; the middle value lies on the limit itself.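

In this assay, fluoro in place of hydrogen gives a number at least 13.5 percentage points lower from compound 1 to compound 4 (beyond the scatter), so the loss seen with methoxy and bromo now appears with a third group at this place on the ring. The steps among compound 2, compound 3 and compound 4 cannot be read, since each of these compounds reports only a limit, so no order among the three groups can be given. At this test concentration, the read-out therefore has little power to separate further changes at this place: the limit of < 10% in this assay, at which 3 of the 4 values shown sit.

From the compounds shown here alone, what an amine or a carboxylic acid at this place would do remains open, including whether either would keep or raise the read-out of compound 1. Going by these compounds, it is also open whether these same groups would lower the read-out if placed elsewhere on the ring.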